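Methyl to vinyl on the aromatic ring

The source may hold more compounds than are shown below. What is called first, only, known or untested is meant among the compounds shown, and "the series" means these compounds.

Measured in a functional assay on HCT-8 cells (Homo sapiens) for cytotoxicity; a higher number here means that more compound is needed for the effect, a lower number that less compound is needed:
Compound 1 `COC1=C(C)C(=O)/C(=C(O)/C=C/c2ccc(Br)cc2)C(=O)C1(C)C`: 7.4 ug/mL
Compound 2 `COC1=C(C)C(=O)/C(=C(O)/C=C/c2ccc(F)cc2)C(=O)C1(C)C`: 3.6 ug/mL
Compound 3 `COC1=C(C)C(=O)/C(=C(O)/C=C/c2ccccc2C)C(=O)C1(C)C`: 4 ug/mL

Compound 3 sits within the scatter of both other compounds, as shown by a 1.1-fold higher number from compound 2 to compound 3 (0.05 log units; within the scatter) and a 1.9-fold lower number from compound 1 to compound 3 (0.27 log units; within the scatter). Compound 4 `C=Cc1ccccc1/C=C/C(O)=C1/C(=O)C(C)=C(OC)C(C)(C)C1=O` differs from it as follows: vinyl in place of methyl on an aromatic carbon. Among the compounds with values here, no measured step makes this exact change. The closest evidence comes from swaps of substituents on the aromatic ring, and the largest, a 2.1-fold lower number from compound 1 to compound 2 (0.31 log units; beyond the scatter), is only modest. A shift beyond the scatter in this assay is therefore not expected. The expected step is a 1.1-fold higher number from compound 3 to compound 4 (0.05 log units; within the scatter). Compound 4 is estimated at 4.5 ug/mL, with an expected range of 2.2 ug/mL to 9 ug/mL.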

Compound 4, concentration for half-maximal effect: 2.1 ug/mL
Beside the measured number, compound 4's estimate is 2.1-fold (0.33 log units) above it, outside the stated range (below it).
By their numbers in this assay, from the lowest: compounds 4, 2, 3 and 1 (each within the scatter of the next, the first and the last beyond it).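

In this assay, vinyl in place of methyl on this aromatic carbon, ortho to a large group, gives a 1.9-fold lower number from compound 3 to compound 4 (0.28 log units; within the scatter) and so leaves the number level. Compound 4 also stays level with the fluoro analogue, with a 1.7-fold lower number from compound 2 to compound 4 (0.23 log units; within the scatter), and only a 3.5-fold lower number from compound 1 to compound 4 (0.55 log units; beyond the scatter) clears the scatter, modestly, as 2-vinylphenyl replaces 4-bromophenyl. Nothing measured here accounts for these numbers.

The compounds shown leave open how an ethyl group, a longer chain or an amine on the same aromatic carbon would compare with vinyl.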